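The compounds below may be only part of what the source reports. "The series", "measured", "known", "first", "only" and "open" are said of these compounds alone.

Measured compounds:
Compound 1, `CCCCCCCNc1cnc(C(=O)NCc2ccccc2)cn1`, gives >= 100000 nM in an ADME assay on Vero cells (Chlorocebus sabaeus) for cytotoxicity, read by microscopy, with a stated time of 6 days; a lower number here means that less compound is tolerated, a higher number that more compound is tolerated; this is a limit of the assay.
Compound 2, `CCCCCCCCNc1nccnc1C(=O)NCc1ccccc1`, gives > 100000 nM in this assay; this too is a limit of the assay.
Compound 3, `CCCCCCCCNc1cnc(C(=O)NCc2ccccc2)cn1`, gives 20000 nM in this assay.

Compound 2 therefore stands at the upper end of the numbers shown, at the limit of > 100000 nM in this assay, at which 1 of the 3 values shown sits, with no number of its own. Among the compounds with values here, the only measured step in this set runs an at least 5.0-fold lower number from compound 1 to compound 3 (0.69 log units; beyond the scatter); the change there is methyl in place of hydrogen on a saturated chain carbon, seven bonds along the chain from a nitrogen on an aromatic ring, and it lowered the number beyond the scatter.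

Compound 4, `CCCCCNc1nccnc1C(=O)NCc1ccccc1`, is not yet measured. Its difference from compound 2 is hydrogen in place of propyl on a saturated chain carbon, five bonds along the chain from a nitrogen on an aromatic ring. The step from compound 1 to compound 3 bears on it only loosely: there a longer chain went with a lower number, and here the chain becomes shorter. Any expected movement in this assay is therefore toward a higher number or none beyond the scatter, and since compound 2 already sits at the limit, compound 4 is expected to remain there. The estimate for compound 4 is 100000 nM, within 50000 nM to 300000 nM, which means an expected step of a number no higher from compound 2 to compound 4 (the limit leaves the size open).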

Compound 4, minimum cytotoxic concentration: > 100000 nM
Compound 4: only a limit was reported (the forecaster's own chance of this, stated with the estimate: 85%); the middle value sits exactly at the limit.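

In this assay compound 4 gives > 100000 nM, a limit of the assay. Compound 2 also stands at a limit, so no step can be read between compound 2 and compound 4. The compounds shown leave open where the actual numbers for these two compounds lie.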